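A few compounds are considered here, and "the series" means these few. Any claim that something is new, unique, unknown or untested is made for them only; others in the source may bear on it.

Measured compounds and their values:

compound 1, `Cc1ccc([C@@H]2CC(=O)c3ccc(F)cc3O2)cc1`, 150 nM 

compound 2, `O=C1C[C@@H](c2ccc(F)cc2)Oc2cc(F)ccc21`, 170 nM 

compound 3, `Cc1ccc2c(c1)OC(c1ccc(F)cc1)CC2=O`, 130 nM 

All three were tested in an in vitro assay on BTI-TN-5B1-4 cells for inhibition of Amine oxidase [flavin-containing] B (Homo sapiens) (a lower number here means a stronger inhibitor, a higher number a weaker inhibitor), and their three numbers lie within the usual scatter of one another, so no order among them can be read out. Compound 1 and compound 2 differ in one place: fluoro in place of methyl on an aromatic carbon. That change gave a 1.1-fold higher number from compound 1 to compound 2 (0.05 log units; within the scatter). How the core of compound 3 differs from that of compound 1 is not broken down here.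

Compound 4, `O=C1CC(c2ccc(F)cc2)Oc2cc(F)ccc21`, is not yet measured. It differs from compound 3 by fluoro in place of methyl on an aromatic carbon. Among the measured compounds shown here, this is the same kind of change as the one from compound 1 to compound 2, but the place is not identical: in the earlier pair the carbon was para to a large group, whereas here it is part of a fused or bridged system of two rings, meta to a fused ring and para to a fused ring. Because the earlier step of a 1.1-fold higher number from compound 1 to compound 2 (0.05 log units; within the scatter) was small, a similarly small step, a 1.2-fold higher number from compound 3 to compound 4 (0.06 log units; within the scatter), is expected here. Compound 4 is therefore estimated to give 150 nM in this assay, with a likely range from 70 nM to 320 nM.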

Compound 4, half-maximal inhibitory concentration: 670 nM
For compound 4 the middle estimate is 4.5-fold (0.65 log units) below the measured one, outside the stated range (above it).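

In this assay, fluoro in place of methyl gave a 5.2-fold higher number from compound 3 to compound 4 (0.71 log units; beyond the scatter), so this change did not carry over from one core to the other with the same size: the same change on two cores in this assay, a 1.1-fold higher number (0.05 log units; within the scatter) from compound 1 to compound 2 and a 5.2-fold higher number (0.71 log units; beyond the scatter) from compound 3 to compound 4, 4.5-fold (0.66 log units) apart, beyond the scatter of two such steps. Two pairs show that the step depends on its setting, but they do not show which feature of the core matters. Compound 2 and compound 4 have the same atoms and bonds, yet a 3.9-fold higher number from compound 2 to compound 4 (0.60 log units; beyond the scatter) cannot be tied to a single cause, and the drawings add a further uncertainty to the comparison: the fact that one of compounds 2 and 4 is drawn with a defined configuration and the other without, at the place where they differ.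

The compounds shown leave open how other groups on this aromatic carbon, such as chloro or methoxy, would behave on each core. They also leave open what value compound 4 would give with a defined configuration.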